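Swapping the end ring of a growth inhibitor

The compounds below may be only part of what the source reports. "The series", "measured", "known", "first", "only" and "open" are said of these compounds alone.

Values measured in a functional assay on A549 cells (Homo sapiens) for inhibition, read by sulforhodamine B assay (on this read-out lower numbers stand for stronger inhibition of growth and higher numbers for weaker inhibition of growth), are as follows.

Compound 1 `Cc1ccc2[nH]c(-c3ccc(-c4ccc(-c5cccc(Cl)c5)cc4)cc3)nc2c1` gives 2800 nM
Compound 2 `COc1cc(-c2ccc(-c3ccc(-c4nc5cc(C)ccc5[nH]4)cc3)cc2)cc(OC)c1OC` gives < 100 nM
Compound 3 `COc1ccc(-c2ccc(-c3ccc(-c4nc5c(O)cccc5[nH]4)cc3)cc2)cc1OC` gives 1310 nM

Compound 1 has the higher of the two exact numbers, so it is the weaker of those two growth inhibitors. Compound 3 is its nearest neighbour, and the gap between them lies just beyond the usual scatter of repeated measurements. Compound 2 gives < 100 nM as its result, which is a limit of the assay and not a number.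

Compound 4 `Cc1ccc2[nH]c(-c3ccc(-c4ccc(-c5ccc(C(F)(F)F)cc5)cc4)cc3)nc2c1` is still unmeasured. It keeps the core of compound 1 and carries 4-(trifluoromethyl)phenyl in place of 3-chlorophenyl on an aromatic carbon. Going by the values given here, no measured pair isolates this swap, so its size can only be judged loosely. Compound 1, at 2800 nM in this series, is the closest reference, and the new ring is again a six-membered aromatic ring of carbon only. In this assay a small step is expected, most likely none beyond the scatter, with no firm direction. For compound 4 the estimated value is 2000 nM with an expected range from 500 nM to 8000 nM for a measurement. This estimate means an expected change of a 1.4-fold lower number from compound 1 to compound 4 (0.15 log units; within the scatter) on this read-out.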

Compound 4, concentration for 50% growth inhibition: 3520 nM
Compound 4: the middle estimate sits 1.8-fold (0.25 log units) below what was measured; the range from low to high includes it.
By their numbers in this assay, from the lowest: compound 3; then compounds 1 and 4 (each within the scatter of the next). At a limit, below all of these: compound 2.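

Going by these compounds alone, the swap gives the first step that can be read directly: in this assay the step is a 1.3-fold higher number from compound 1 to compound 4 (0.10 log units; within the scatter) and so compound 1 and compound 4 cannot be told apart on this read-out. At this place on the molecule, 3-chlorophenyl can give way to 4-(trifluoromethyl)phenyl, a group of 10 heavy atoms in place of 7 that still has no hydrogen-bond donors or acceptors, with no readable shift in growth inhibition. Compound 2 alone stands at a limit of the assay and not at a number, so this step rests on two exact values: the limit of < 100 nM in this assay, at which 1 of the 4 values shown sits.

The swap changes both the group on the end ring and where that group sits, so the compounds shown cannot say how much each of the two counts on its own. From the compounds shown here alone, whether this place would also accept an end ring carrying an amine or a carboxylic acid, or a longer chain in place of that ring, stays open.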